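The source may hold more compounds than are shown below. What is called first, only, known or untested is meant among the compounds shown, and "the series" means these compounds.

The measured compounds:

Compound 1, `CCOC(=O)C1C(=O)C=C(Nc2ccc(N3CCN(CC)CC3)cc2)CC1c1ccccc1`: 4.77
Compound 2, `COC(=O)C1C(=O)C=C(Nc2cccc(N3CCN(C)CC3)c2)CC1c1ccccc1`: 3.99
Compound 3, `CCOC(=O)C1C(=O)C=C(Nc2ccc(N3CCN(CC)CC3)cc2)CC1C`: 3.45

In a physicochemical assay for lipophilicity (on this read-out lower numbers stand for lower lipophilicity and higher numbers for higher lipophilicity), compound 1 gives 4.77, the highest of the three numbers. Compound 3, `CCOC(=O)C1C(=O)C=C(Nc2ccc(N3CCN(CC)CC3)cc2)CC1C`, is compound 1 with methyl in place of phenyl on a saturated ring carbon, and this change made a step of a number 1.32 log units lower from compound 1 to compound 3 (beyond the scatter). Compound 2, `COC(=O)C1C(=O)C=C(Nc2cccc(N3CCN(C)CC3)c2)CC1c1ccccc1`, has a different core; the difference between the two cores is not broken down here. In this assay compound 2 gives 3.99, which stands between the values of compound 1 and compound 3.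

Compound 4, `COC(=O)C1C(=O)C=C(Nc2cccc(N3CCN(C)CC3)c2)CC1C`, has not yet been measured. It is compound 2 with methyl in place of phenyl on a saturated ring carbon. For the measured compounds named here, this is the same kind of change as the one from compound 1 to compound 3, not the same change: in compound 1 the place lies by the ring atom that bears an ethoxycarbonyl group (5 heavy atoms), in compound 2 by the ring atom that bears a methoxycarbonyl group (4 heavy atoms). Since the step from compound 1 to compound 3 was a number 1.32 log units lower from compound 1 to compound 3 (beyond the scatter), a step of about the same size is expected from compound 2 to compound 4, namely a number 1.32 log units lower from compound 2 to compound 4 (beyond the scatter) in this assay. On that basis compound 4 is estimated to give 2.67 in this assay, expected to fall between 2.25 and 3.1.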

Compound 4, partition coefficient: 2.67
Compound 4: the middle estimate sits on the measured number at the digits printed; the measured number falls inside the stated range.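

In this assay, replacing phenyl with methyl on a saturated ring carbon gave a step of a number 1.32 log units lower from compound 2 to compound 4 (beyond the scatter), the same at the digits printed as the step of a number 1.32 log units lower from compound 1 to compound 3 (beyond the scatter). The change therefore carried over from the one core to the other at full size in these two pairs, even though the place lies by the ring atom that bears an ethoxycarbonyl group in compound 1 and a methoxycarbonyl group in compound 2. This rests on only two pairs, so it does not show that the step would keep its size on any further core or that other changes would carry over in the same way, and nothing shown explains why the two steps agree.

The compounds shown leave open how other groups on this saturated ring carbon would compare with phenyl and methyl, for example ethyl as a longer chain, an amine or a carboxylic acid. They also leave open whether the step would keep its size with a group other than methoxycarbonyl or ethoxycarbonyl on the neighbouring ring atom, such as a carboxylic acid in place of the ester.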